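The source may hold more compounds than are shown below. What is called first, only, known or untested is meant among the compounds shown, and "the series" means these compounds.

Working notes on the series, read in a functional assay on Rec1 cells (Homo sapiens) for inhibition, read by luminescence and CellTiter-Glo, with a stated time of 72 h; a higher number here means a weaker inhibitor, a lower number a stronger inhibitor. Compound 2 (`C/C=C/C(=O)Nc1ccc(Cn2nc(-c3ccc(Oc4ccccc4)cc3)cc2C(=O)OCC)cc1`) gives 13100 nM, and both neighbouring values lie within the scatter of it: compound 3 (`C/C=C/C(=O)Nc1ccc(Cn2nc(-c3ccc(Oc4ccccc4)cc3)cc2CO)cc1`) at 12200 nM and compound 1 (`C/C=C/C(=O)Nc1cccc(Cn2nc(-c3ccc(Oc4ccccc4)cc3)cc2C(=O)O)c1`) at 26000 nM.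

Compound 4 (`C/C=C/C(=O)Nc1cccc(Cn2nc(-c3ccc(Oc4ccccc4)cc3)cc2C(=O)OCC)c1`) keeps the ethoxycarbonyl of compound 2 and changes one thing: 3-(((prop-1-en-1-yl)carbonyl)amino)phenyl in place of 4-(((prop-1-en-1-yl)carbonyl)amino)phenyl on a saturated chain carbon bound to an aromatic nitrogen. The two have the same atoms, joined differently, with the change on a saturated chain carbon bound to an aromatic nitrogen.

Among the compounds with values here, the only measured step, a 1.1-fold lower number from compound 2 to compound 3 (0.03 log units; within the scatter), alters the ethoxycarbonyl instead, so it bears only indirectly on this change. Compound 1 carries the 3-(((prop-1-en-1-yl)carbonyl)amino)phenyl group and gives 26000 nM, but it also lacks the ethoxycarbonyl, so it does not isolate the change. Within the data shown here, no measured step isolates this change, and no shift beyond the scatter is expected in this assay. The expected step is a 1.1-fold lower number from compound 2 to compound 4 (0.04 log units; within the scatter). Compound 4 is estimated at 12000 nM, with an expected range of 4500 nM to 30000 nM.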

Compound 4, half-maximal inhibitory concentration: 7800 nM
Compound 4: middle estimate off by 1.5-fold (0.19 log units), on the high side; the range from low to high includes it.
By their numbers in this assay, from the lowest: compounds 4, 3, 2 and 1 (each within the scatter of the next, the first and the last beyond it).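

Swapping the 4-(((prop-1-en-1-yl)carbonyl)amino)phenyl for the 3-(((prop-1-en-1-yl)carbonyl)amino)phenyl on a saturated chain carbon bound to an aromatic nitrogen gives a 1.7-fold lower number from compound 2 to compound 4 (0.23 log units; within the scatter) in this assay, so this position tolerates the change without a shift beyond the scatter. Within the data shown here, with the 3-(((prop-1-en-1-yl)carbonyl)amino)phenyl held fixed, the ester can now be read on its own: a 3.3-fold lower number from compound 1 to compound 4 (0.52 log units; beyond the scatter) is the first step beyond the scatter, though only a modest one. No supporting data bear on what lies behind either step.

Open, on these data alone, is whether a longer chain on that oxygen, or an amine in place of the ethoxy group, would move the number further. Also open, as far as these compounds go, is whether the hydroxymethyl of compound 3 would match the ethoxycarbonyl alongside the 3-(((prop-1-en-1-yl)carbonyl)amino)phenyl group.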